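This account rests on a few compounds, and the source may have more. Where it says the series, first, only, none or still open, it means among the compounds named here.

Measured so far in a functional assay for inhibition of sodium/hydrogen exchanger (Oryctolagus cuniculus); a lower number here means a stronger inhibitor, a higher number a weaker inhibitor:
compound 1, `Cc1cc(-c2ccc(Cl)cc2)c(S(C)(=O)=O)cc1C(=O)N=C(N)N`, 45 nM
compound 2, `Cc1cc(OC(C)(C)C)c(S(C)(=O)=O)cc1C(=O)N=C(N)N`, 9.4 nM

Compound 2 has the lowest of the two numbers in this assay; its nearest neighbour is compound 1, separated by a 4.8-fold lower number from compound 1 to compound 2 (0.68 log units; beyond the scatter), a step beyond the scatter. Compound 3, `Cc1ccc(S(C)(=O)=O)cc1C(=O)N=C(N)N`, has not yet been measured. It differs from compound 2 in one place: hydrogen in place of tert-butoxy on an aromatic carbon. Among the measured compounds shown here, the only measured step that bears on this position is a 4.8-fold lower number from compound 1 to compound 2 (0.68 log units; beyond the scatter), where a different group stood on the same aromatic carbon, ortho to the methylsulfonyl group. That step shows this position can move the number modestly, but it gives no direct reading for hydrogen there. Because a 4.8-fold lower number from compound 1 to compound 2 (0.68 log units; beyond the scatter) puts the tert-butoxy group at the lowest number seen, compound 3 is expected to give a higher number, by about a 4.3-fold higher number from compound 2 to compound 3 (0.63 log units; beyond the scatter). Compound 3 is estimated at 40 nM, with a range from 10 nM to 200 nM.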

Compound 3, half-maximal inhibitory concentration: 150 nM
The estimate for compound 3 lay 3.8-fold (0.57 log units) below the measured number, and the stated range covers the measured number.
By their numbers in this assay, from the lowest: compound 2; then compound 1; then compound 3.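

Hydrogen gives the highest number of the three in this assay, so this aromatic carbon does not merely tolerate a substituent: both groups tried there give a lower number than no group at all. The size of that gain depends on the group, with a 16-fold higher number from compound 2 to compound 3 (1.20 log units; beyond the scatter) for the loss of tert-butoxy, a large step, against a 3.3-fold higher number from compound 1 to compound 3 (0.52 log units; beyond the scatter) for the loss of 4-chlorophenyl, a modest one. Nothing shown explains this difference between the two groups.

Among the compounds shown here, with only two groups to compare with hydrogen, the compounds leave open whether a smaller ether such as methoxy, an amine or an unsubstituted phenyl would also lower the number. They also leave open whether the gain from tert-butoxy would hold if the methyl or methylsulfonyl group of the shared core were replaced.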